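A few compounds are considered here, and "the series" means these few. Any claim that something is new, unique, unknown or untested is made for them only; others in the source may bear on it.

Measured compounds:
- Compound 1, `CN1CCC[C@H]1[C@H]1COc2ccc(CO)cc2O1`: 9500 nM
- Compound 2, `CN1CCC[C@@H]1[C@H]1COc2ccc(O)cc2O1`: 3500 nM
- Compound 3, `CN1CCC[C@H]1[C@@H]1COc2ccc(O)cc2O1`: 12 nM

These three compounds were tested in an assay on Cerebral cortex (strain Sprague-Dawley) for displacement of a labelled ligand from Neuronal acetylcholine receptor; alpha4/beta2 (Rattus norvegicus); on this read-out higher numbers stand for weaker inhibition and lower numbers for stronger inhibition. Compound 3 gives 12 nM, the lowest number of the three. Compound 2, its mirror image, gives 3500 nM, and compound 1, which carries a hydroxymethyl group in place of the hydroxyl group, gives 9500 nM.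

The step now followed leads from compound 3 to compound 4, `CN1CCC[C@H]1[C@H]1COc2ccc(O)cc2O1`. the two compounds have the same atoms and bonds and differ only in configuration as drawn: 1 of 2 stereo elements differ; a stereocentre at a saturated ring carbon is drawn R in compound 3 and S in compound 4 Compound 4 is therefore neither compound 3 nor its mirror image, but a third arrangement of the same atoms.

For the measured compounds named here, only one measured step bears on this change: a 290-fold lower number from compound 2 to compound 3 (2.46 log units; beyond the scatter), which rests on (the fact that compounds 2 and 3 differ only in the configuration as drawn). Inverting both stereocentres moved the number far beyond the scatter, so inverting one of them is expected to matter as well, most likely in the direction of a higher number, though the size cannot be read off directly. Compound 4 is estimated to show a 33-fold higher number from compound 3 to compound 4 (1.52 log units; beyond the scatter) in this assay, giving about 400 nM, within a range from 40 nM to 4000 nM.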

Compound 4, inhibition constant: 421 nM
Estimate against measurement, compound 4: 1.1-fold (0.02 log units) below; the range from low to high includes it.
By their numbers in this assay, from the lowest: compound 3; then compound 4; then compound 2; then compound 1.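

In this assay, each of the two stereocentres counts on its own, and they do not count equally: inverting one gives a 35-fold higher number from compound 3 to compound 4 (1.55 log units; beyond the scatter), a large step, while inverting the other gives an 8.3-fold lower number from compound 2 to compound 4 (0.92 log units; beyond the scatter), a modest one. Both steps come from the arrangement in space alone, with nothing added or removed: the fact that compounds 3 and 4 differ only in the configuration as drawn. With the configuration held fixed, hydroxy in place of hydroxymethyl on an aromatic carbon also has a clear effect, giving a 23-fold lower number from compound 1 to compound 4 (1.35 log units; beyond the scatter).

On these data alone, whether hydroxy has a step of similar size in the configuration of compound 3 remains open. So does how a methoxy group or an amine on that aromatic carbon would compare with hydroxy.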